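Replacing 3,4-dimethoxyphenyl with 4-fluorophenyl: working notes

This account rests on a few compounds, and the source may have more. Where it says the series, first, only, none or still open, it means among the compounds named here.

Values in a functional assay on PC-3 cells (Homo sapiens) for cytotoxicity, read by sulforhodamine B assay, with a stated time of 48 h (a lower number here means a stronger inhibitor, a higher number a weaker inhibitor), follow.
compound 1 `C[C@H]1CC[C@@H]2[C@@H](OC(=O)[C@]23CC(c2ccccc2[N+](=O)[O-])=NO3)[C@]2(C)C(=O)C=C[C@@]12O` 37000 nM
compound 2 `COc1ccc(C2=NO[C@]3(C2)C(=O)O[C@@H]2[C@H]3CC[C@H](C)[C@]3(O)C=CC(=O)[C@@]23C)cc1OC` 25000 nM
compound 3 `C[C@H]1CC[C@@H]2[C@@H](OC(=O)[C@]23CC(c2ccccc2F)=NO3)[C@]2(C)C(=O)C=C[C@@]12O` 8200 nM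

Compound 2 stands in the upper part of this small range: a 1.5-fold lower number from compound 1 to compound 2 (0.17 log units; within the scatter) stays within the scatter, while a 3.0-fold lower number from compound 2 to compound 3 (0.48 log units; beyond the scatter) goes beyond it. Compound 4 `C[C@H]1CC[C@@H]2[C@@H](OC(=O)[C@]23CC(c2ccc(F)cc2)=NO3)[C@]2(C)C(=O)C=C[C@@]12O` differs from compound 2 at one place: 4-fluorophenyl in place of 3,4-dimethoxyphenyl on a carbon with a double bond to nitrogen on a carbon with a double bond to nitrogen. The nearest guide is a 3.0-fold lower number from compound 2 to compound 3 (0.48 log units; beyond the scatter) for the same 3,4-dimethoxyphenyl leaving, though with 2-fluorophenyl entering. The other fluoro step, a 4.5-fold lower number from compound 1 to compound 3 (0.65 log units; beyond the scatter) starts from a nitro compound. Among the compounds with values here, no measured compound carries 4-fluorophenyl. A modest lowering is therefore expected in this assay with a 2.5-fold lower number from compound 2 to compound 4 (0.40 log units; beyond the scatter) as the expected step. Compound 4 is estimated at 10000 nM with 4000 nM to 25000 nM as the expected range.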

Compound 4, half-maximal inhibitory concentration: 27000 nM
Compound 4: middle estimate off by 2.7-fold (0.43 log units), on the low side; the whole stated range lies below it.
By their numbers in this assay, from the lowest: compound 3; then compounds 2, 4 and 1 (each within the scatter of the next).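

A fluoro group on the phenyl ring does not by itself bring a lower number at this position: 4-fluorophenyl gives a 1.1-fold higher number from compound 2 to compound 4 (0.03 log units; within the scatter) and a 1.4-fold lower number from compound 1 to compound 4 (0.14 log units; within the scatter). The place of the fluoro on the ring does count, as moving from 2-fluorophenyl to 4-fluorophenyl gives a 3.3-fold higher number from compound 3 to compound 4 (0.52 log units; beyond the scatter), which leaves compound 3 alone apart from the other three. Nothing available bears on why these two fluoro groups differ.

As far as these compounds go, whether 2-chlorophenyl or 2-methylphenyl would stay with 2-fluorophenyl or with 2-nitrophenyl remains open.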